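This account rests on a few compounds, and the source may have more. Where it says the series, first, only, none or still open, it means among the compounds named here.

Compound 1 `CC(Nc1nc(N)nc2ccc(-c3cnn(C)c3)cc12)c1c(Cl)ccc(F)c1Cl` gives > 100000 nM in a functional assay on A549 cells (Homo sapiens) for antiproliferative activity, read by MTT assay, with a stated time of 72 h; a lower number here means a stronger inhibitor, a higher number a weaker inhibitor.
Compound 2 `COc1cccc(CNc2ncnc3ncc(-c4cnn(C)c4)cc23)c1` gives > 100000 nM in this assay.
Compound 3 `CC(Oc1ncnc2ccc(-c3cnn(C)c3)cc12)c1c(Cl)ccc(F)c1Cl` gives 28800 nM in this assay.

Compound 2 does not have a number of its own in this assay, only a limit: it stands at the limit of > 100000 nM in this assay, at which 2 of the 3 values shown sit. Compound 4 `Cn1cc(-c2cnc3ncnc(NCc4cccc([N+](=O)[O-])c4)c3c2)cn1` differs from compound 2 in one place, (nitro in place of methoxy on an aromatic carbon). Going by the values given here, no pair of measured compounds shows what such a swap does here, and the only compound with a numerical value, compound 3, carries a different linker and a different side group, so it gives no guide. The step from compound 2 to compound 4 in this assay is expected to stay within the scatter, with compound 4 most likely again reported only as a limit. Compound 4 is therefore estimated at 100000 nM, in a range from 20000 nM to 300000 nM, an expected step of a number no higher from compound 2 to compound 4 (the limit leaves the size open).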

Compound 4, half-maximal inhibitory concentration: > 100000 nM
Compound 4 ended at the assay's limit (the forecaster's own chance of this, stated with the estimate: 70%); the middle value sits exactly at the limit.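

Going by these compounds alone, compound 2 and compound 4 both stand only at a limit in this assay, and no step between them can be read. The compounds shown leave open whether nitro in place of methoxy changes activity at all.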